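This account rests on a few compounds, and the source may have more. Where it says the series, first, only, none or still open, it means among the compounds named here.

Measured compounds in a functional assay on HEK293 cells for agonist activity at Bile acid receptor (Homo sapiens); on this read-out higher numbers stand for larger maximal responses and lower numbers for smaller maximal responses:

compound 1 `CC(C)c1onc(-c2c(Cl)cccc2Cl)c1COc1ccc(N(C)C(=O)c2ccc(C(=O)O)cc2)c(C(F)(F)F)n1` gives 36%
compound 2 `CC(C)c1onc(-c2c(Cl)cccc2Cl)c1COc1ccc(NC(=O)c2ccc(C(=O)O)cc2)c(C(F)(F)F)n1` gives 21%
compound 3 `CC(Nc1ccc(C(=O)O)cc1)c1ccc(OCc2c(-c3c(Cl)cccc3Cl)noc2C2CC2)nc1C(F)(F)F` gives 59%

Compound 3 stands highest of the three, beyond the scatter from both of the others. Compounds 1 and 2 share one core and differ in a single place: methyl in place of hydrogen on an amide-type nitrogen. This change gave a number 15 percentage points higher from compound 2 to compound 1 (beyond the scatter), a modest gain in this assay.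

Compound 4 `CC(c1ccc(OCc2c(-c3c(Cl)cccc3Cl)noc2C2CC2)nc1C(F)(F)F)N(C)c1ccc(C(=O)O)cc1` has not yet been measured in this assay. It is built on the core of compound 3, and the difference between the two cores, that of compound 2 and that of compound 3, is not broken down here. Compound 4 differs from compound 3 in one place: methyl in place of hydrogen on a nitrogen on an aromatic ring. Among the measured compounds shown here, this is the same kind of change as the one from compound 2 to compound 1, a methyl in place of hydrogen on a nitrogen, but not the same: in compound 1 the nitrogen is an amide-type nitrogen whose other neighbours are an aromatic carbon and a carbonyl carbon, whereas in compound 4 the nitrogen sits on an aromatic ring and its other neighbours are an aromatic carbon and a saturated chain carbon.

For the measured compounds named here, since the one measured example of this kind of change gave a number 15 percentage points higher from compound 2 to compound 1 (beyond the scatter), a gain of similar size is expected here, with room on either side given the different surroundings: the step from compound 3 to compound 4 is estimated at a number 13 percentage points higher from compound 3 to compound 4 (beyond the scatter). Compound 4 is therefore expected to reach about 72%, estimated between 52% and 92%.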

Compound 4, largest response reached (reported as efficacy), in percent of the reference or control that the assay uses: 55%
Compound 4: middle estimate off by 17 percentage points, on the high side; the measured number falls inside the stated range.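

In this assay, placing a methyl on the nitrogen on an aromatic ring, where a hydrogen stood before, gave a number 4 percentage points lower from compound 3 to compound 4 (within the scatter), so on this core the change has no effect that can be told apart from ordinary variation between repeated measurements. The modest gain seen on the other core therefore did not carry over, and the two results differ by more than measurement scatter can explain: the same change on two cores in this assay, a number 15 percentage points higher (beyond the scatter) from compound 2 to compound 1 and a number 4 percentage points lower (within the scatter) from compound 3 to compound 4, 19 percentage points apart, beyond the scatter of two such steps. This shows that, in this series, the effect of this methyl cannot simply be transferred from one core to another, but it does not show why: the two cores differ, the nitrogen is amide-type in one and not in the other, and a single pair on each core cannot separate these differences or support a general rule.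

What an ethyl group or a longer chain would do on either nitrogen remains open, since the compounds shown carry only hydrogen or methyl there. Going by these compounds, it also remains open whether the results would hold with a nitrile in the place of the carboxylic acid, the group found in all four compounds.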